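A few compounds are considered here, and "the series" means these few. Any claim that something is new, unique, unknown or untested is made for them only; others in the source may bear on it.

Compound 3 `COC(=O)C1(c2ccccc2)CC1CN1CCN(c2ccccn2)CC1` carries hydrogen where compounds 1 and 2 carry nitro and methyl on the aromatic carbon. In an assay for displacement of a labelled ligand from Sigma non-opioid intracellular receptor 1 (Cavia porcellus) (on this read-out lower numbers stand for stronger inhibition and higher numbers for weaker inhibition), compound 3 gives 1330 nM, the highest number among the three measured compounds. The nearest is compound 1 `COC(=O)C1(c2ccc([N+](=O)[O-])cc2)CC1CN1CCN(c2ccccn2)CC1`, which gives 769 nM; the step is a 1.7-fold higher number from compound 1 to compound 3 (0.24 log units; within the scatter). Compound 2 `COC(=O)C1(c2ccc(C)cc2)CC1CN1CCN(c2ccccn2)CC1` gives 497 nM, and the step is a 2.7-fold higher number from compound 2 to compound 3 (0.43 log units; beyond the scatter). Between the two substituted compounds the step is a 1.5-fold lower number from compound 1 to compound 2 (0.19 log units; within the scatter).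

Compound 4 `COC(=O)C1(c2ccccc2)CC1CN1CCN(c2ncccn2)CC1` keeps the core of compound 3 and differs by pyrimidin-2-yl in place of pyridin-2-yl on an amine nitrogen in a ring. None of the three measured steps touches this position: each of them alters the group on the aromatic carbon, and the group on the amine nitrogen in the ring is the same in compounds 1, 2 and 3. Going by the values given here, there is therefore no measured step that bears directly on the change from compound 3 to compound 4, and nothing points to a step beyond the scatter in this assay in either direction. The working expectation for compound 4 is 1330 nM, with a range of 600 nM to 3000 nM. The step this estimate implies, no change at the digits printed from compound 3 to compound 4 (within the scatter), is expected to stay within the scatter.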

Compound 4, inhibition constant: 3090 nM
Compound 4: middle estimate off by 2.3-fold (0.37 log units), on the low side; measured number above the stated range.
By their numbers in this assay, from the lowest: compounds 2, 1 and 3 (each within the scatter of the next, the first and the last beyond it); then compound 4.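

The position on the amine nitrogen in the ring, untouched in compounds 1, 2 and 3, turns out to respond in this assay: pyrimidin-2-yl in place of pyridin-2-yl gives a 2.3-fold higher number from compound 3 to compound 4 (0.37 log units; beyond the scatter), a modest step in the weaker direction. The change leaves the count of heavy atoms as it was and swaps one ring carbon for nitrogen, going from one six-membered aromatic ring with 1 hetero atom to one with 2 hetero atoms, so a single atom within the group on this nitrogen is enough to move the number beyond the scatter. No measurement on hand accounts for this step, so the data give the size and direction of the shift and nothing about its origin.

Going by these compounds, the step rests on one pair on the unsubstituted core, and it remains open whether pyrimidin-2-yl has the same effect with nitro or methyl on the aromatic carbon, as in compounds 1 and 2. Also open, on these data alone, is how a plain phenyl or a benzyl group on this amine nitrogen would read against pyridin-2-yl and pyrimidin-2-yl.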